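Lipophilicity notes on the fused dihydropyridine ester series

The compounds below may be only part of what the source reports. "The series", "measured", "known", "first", "only" and "open" are said of these compounds alone.

Measured compounds:
- compound 1 `CC1=C(C(=O)OCc2ccccn2)C(c2cccs2)C2=C(CCCC2=O)N1`: 1.77
- compound 2 `CC1=C(C(=O)OCc2cccnc2)C(c2cccs2)C2=C(CCCC2=O)N1`: 1.4
- compound 3 `CCCC1C(C(=O)OCc2cccnc2)=C(C)NC2=C1C(=O)CCC2`: 2.23

The read-out is a physicochemical assay for lipophilicity, measured as octanol-water partition; on this read-out lower numbers stand for lower lipophilicity and higher numbers for higher lipophilicity. Compound 1 stands second highest of the three values: its nearest neighbour is compound 2, a number 0.37 log units lower from compound 1 to compound 2 (beyond the scatter), and its furthest is compound 3, which sits higher than compound 1 by more than the scatter. Within the data shown here, the only step at the saturated ring carbon is a number 0.83 log units higher from compound 2 to compound 3 (beyond the scatter), a modest but clear rise.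

Compound 4 `CC1=C(C(=O)OCc2ccccn2)C(c2ccc(O)cc2)C2=C(CCCC2=O)N1` is not yet measured. It differs from compound 1 by 4-hydroxyphenyl in place of thiophen-2-yl on a saturated ring carbon. Among the measured compounds shown here, no measured pair swaps thiophen-2-yl for 4-hydroxyphenyl, so the step from compound 2 to compound 3 only shows that changing the group on this ring carbon can move this assay by a modest amount; it gives no direction for the present change. The entering group brings one hydrogen-bond donor where the leaving group brings none. In this assay compound 1 gives 1.77, and a small drop from this value is expected for compound 4, of the order of the step from compound 1 to compound 2.

For compound 4 the expected step is a number 0.37 log units lower from compound 1 to compound 4 (beyond the scatter), and the estimate is 1.4, with a range from 0.9 to 1.9.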

Compound 4, partition coefficient: 1.58
The estimate for compound 4 lay 0.18 log units below the measured number, within the range that was stated.
By their numbers in this assay, from the lowest: compounds 2, 4 and 1 (each within the scatter of the next, the first and the last beyond it); then compound 3.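

In this assay, 4-hydroxyphenyl in place of thiophen-2-yl on the saturated ring carbon gives a number 0.19 log units lower from compound 1 to compound 4 (within the scatter), so this pair cannot be told apart on this read-out, even though the entering group has a six-membered aromatic ring of carbon only and carries a hydrogen-bond donor. Among these compounds, the only earlier step at this carbon, a number 0.83 log units higher from compound 2 to compound 3 (beyond the scatter), put propyl in place of thiophen-2-yl with the pyridin-3-yl ester, so the two entering groups differ in outcome at this position, although the ester also differs between the two pairs. Nothing available explains the result for this pair.

Phenyl and 4-methoxyphenyl on the same carbon would show whether the ring and the hydroxyl group have separate effects in this assay, and the same 4-hydroxyphenyl swap on compound 2 would show whether the result carries over to the pyridin-3-yl ester. Also open is how far this position tolerates other kinds of group, such as a carboxylic acid, an aminomethyl group or a chain longer than propyl, since the compounds shown cover only thiophen-2-yl, 4-hydroxyphenyl and propyl.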